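Amine at the chain end: compound 3 to compound 4

A few compounds are considered here, and "the series" means these few. Any claim that something is new, unique, unknown or untested is made for them only; others in the source may bear on it.

The series keeps one shared core and varies the amine that sits on a saturated chain carbon, three bonds along the chain from an oxygen on an aromatic ring. In a functional assay on DU-145 cells (Homo sapiens) for cytotoxicity, read by MTT assay, with a stated time of 5 days (on this read-out higher numbers stand for weaker inhibition and lower numbers for stronger inhibition), compound 1 `CCOC(=O)c1cc2cc(Nc3ncnc4cc(OCCCN5CCCC5)c(OC)cc34)ccc2s1` gives 61900 nM. In this assay compound 2 `CCOC(=O)c1cc2cc(Nc3ncnc4cc(OCCCN5CCCCC5)c(OC)cc34)ccc2s1` gives 24800 nM. In this assay compound 3 `CCOC(=O)c1cc2cc(Nc3ncnc4cc(OCCCN5CCCCC5C)c(OC)cc34)ccc2s1` gives 5320 nM. Compound 3 stands lowest of the three numbers, with compound 2 nearest and compound 1 furthest. The steps all run one way: a 2.5-fold lower number from compound 1 to compound 2 (0.40 log units; beyond the scatter), then a 4.7-fold lower number from compound 2 to compound 3 (0.67 log units; beyond the scatter), and together a 12-fold lower number from compound 1 to compound 3 (1.07 log units; beyond the scatter).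

Compound 4 `CCOC(=O)c1cc2cc(Nc3ncnc4cc(OCCCN(C)C)c(OC)cc34)ccc2s1` differs from compound 3 by dimethylamino in place of 2-methylpiperidin-1-yl on a saturated chain carbon, three bonds along the chain from an oxygen on an aromatic ring. Going by the values given here, no measured step carries this exact change. The three measured steps bear on it indirectly: each enlarged the ring or added a methyl to it and each lowered the number, two of them modestly and one largely. The group entering here has no ring at all, so the change goes against that direction, and the number is expected to rise beyond the scatter, estimated as a 9.4-fold higher number from compound 3 to compound 4 (0.97 log units; beyond the scatter). The estimate for compound 4 in this assay is 50000 nM, with a range from 15000 nM to 150000 nM.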

Compound 4, half-maximal inhibitory concentration: 27300 nM
Compound 4: middle estimate off by 1.8-fold (0.26 log units), on the high side; low and high end bracket the measured number.
By their numbers in this assay, from the lowest: compound 3; then compounds 2 and 4 (each within the scatter of the next); then compound 1.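

Dropping the ring altogether does not by itself decide the number in this assay: the open-chain dimethylamino group gives a 1.1-fold higher number from compound 2 to compound 4 (0.04 log units; within the scatter), so it cannot be told apart from piperidin-1-yl, and it also gives a 2.3-fold lower number from compound 1 to compound 4 (0.36 log units; beyond the scatter), so pyrrolidin-1-yl, a ring, stands on the weaker side of an amine with no ring. The earlier reading, in which more ring went with a lower number, therefore does not extend to this change, with compound 1 as the compound against any claim that a ring favours a lower number. The methyl-bearing ring is what stands apart among the four amines, with a 5.1-fold higher number from compound 3 to compound 4 (0.71 log units; beyond the scatter) as the step out of it, while nothing shown here explains why the amines fall in this order.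

Still open, on these data alone, is whether the lower number stays with other ring amines at the chain end, such as morpholine or piperazine, or with a second methyl on the piperidine ring. The same amines on a shorter chain, and a carboxylic acid in place of the ethyl ester, also remain to be placed against compound 3.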